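Nitro on the anilino ring of compound 4

The source may report more compounds than this note shows. Statements on the series, on what has been measured and on what is new or still open speak of the compounds shown alone.

Of the compounds shown here, three sharing one core have been measured in a functional assay on MCF7 cells (Homo sapiens) for cytotoxicity, read by MTT assay, with a stated time of 72 h; a higher number here means a weaker inhibitor, a lower number a stronger inhibitor. Compound 1 `CCCCCCCCNc1nc(SCc2ccc(C(F)(F)F)cc2)nc2ccccc12` gives 26100 nM, compound 2 `FC(F)(F)c1ccc(CSc2nc(Nc3ccccc3)c3ccccc3n2)cc1` gives 44000 nM, and compound 3 `Cc1ccccc1Nc1nc(SCc2ccc(C(F)(F)F)cc2)nc2ccccc12` gives 37500 nM. Compound 2 shows the highest of the three numbers, yet a 1.7-fold higher number from compound 1 to compound 2 (0.23 log units; within the scatter) and a 1.2-fold lower number from compound 2 to compound 3 (0.07 log units; within the scatter) both lie within the scatter, so the three cannot be told apart. Compound 4 `O=[N+]([O-])c1cccc(Nc2nc(SCc3ccc(C(F)(F)F)cc3)nc3ccccc23)c1` differs from compound 2 by nitro in place of hydrogen on an aromatic carbon. Within the data shown here, the nearest precedent is the change on the same ring, a 1.2-fold lower number from compound 2 to compound 3 (0.07 log units; within the scatter), which stayed within the scatter, as did a 1.4-fold higher number from compound 1 to compound 3 (0.16 log units; within the scatter). Among the measured compounds shown here, no measured step here moved beyond the scatter, so for compound 4 the expected step is a 1.1-fold lower number from compound 2 to compound 4 (0.04 log units; within the scatter). Compound 4 is therefore estimated at 40000 nM, within 18000 nM to 90000 nM.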

Compound 4, half-maximal inhibitory concentration: > 50000 nM
Compound 4: a limit, no number (the forecaster's own chance of this, stated with the estimate: 10%); middle value at least 1.2-fold (0.09 log units) away from the limit.
By their numbers in this assay, from the lowest: compounds 1, 3 and 2 (each within the scatter of the next). At a limit, above all of these: compound 4.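

In this assay compound 4 gives no number, only a limit: the limit of > 50000 nM in this assay, at which 1 of the 4 values shown sits.

Nitro on this aromatic carbon gives an at least 1.1-fold higher number from compound 2 to compound 4 (0.05 log units; that floor lies within the scatter), while the wider changes give an at least 1.3-fold higher number from compound 3 to compound 4 (0.12 log units; that floor lies within the scatter) and an at least 1.9-fold higher number from compound 1 to compound 4 (0.28 log units; that floor lies within the scatter). Among these compounds, these are only floors, so the true size of each step is unknown, but unlike the earlier compounds, this one yields no measurable number, and nitro here brought no lower number.

On these data alone, whether an amine or a carboxylic acid on this carbon would return a measurable number stays open. So does the effect of moving the nitro elsewhere on this ring.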